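A few compounds are considered here, and "the series" means these few. Any claim that something is new, unique, unknown or untested is made for them only; others in the source may bear on it.

Notes on the series

Two compounds share the core and carry a benzyl substituent on the triazole. Compound 1 `Cc1cccc(Cn2cc(COc3ccc4c(=O)ccoc4c3)nn2)c1` bears a methyl on that ring, and in a functional assay on A549 cells (Homo sapiens) for cytotoxicity, read by MTT assay, with a stated time of 48 h (on this read-out higher numbers stand for weaker inhibition and lower numbers for stronger inhibition), compound 1 gives 20300 nM. Compound 2 `CC(C)(C)c1ccc(Cn2cc(COc3ccc4c(=O)ccoc4c3)nn2)cc1` carries a tert-butyl instead. In this assay compound 2 returns only a limit, > 100000 nM, so its position is known merely as one of the two values sitting at the limit of > 100000 nM in this assay, at which 1 of the 2 values shown sits; no number stands for it.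

The next compound, compound 3 `O=c1ccoc2cc(OCc3cn(Cc4ccc(Cl)cc4)nn3)ccc12`, differs from compound 2 by chloro in place of tert-butyl on an aromatic carbon, on an aromatic carbon of a six-membered aromatic ring of carbon only, para to a large group. Going by the values given here, no measured pair of this kind exists, so the size of the step is open. A move toward stronger inhibition is expected, since compound 1 with a smaller substituent gives 20300 nM; the step from compound 2 is estimated as an at least 3.3-fold lower number from compound 2 to compound 3 (0.52 log units; beyond the scatter). For compound 3 the estimate in this assay is 30000 nM, within 8000 nM to 100000 nM.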

Compound 3, half-maximal inhibitory concentration: > 100000 nM
Compound 3: a limit, no number; the forecaster's own chance of this, stated with the estimate: 35%; middle value at least 3.3-fold (0.52 log units) away from the limit.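

Exchanging tert-butyl for chloro on this ring does not bring the read-out in this assay off the limit: compound 3, like compound 2, returns only a limit and no number, so the step between them cannot be read. The exchange of 3-methylphenyl for 4-chlorophenyl, on the other hand, gives an at least 4.9-fold higher number from compound 1 to compound 3 (0.69 log units; beyond the scatter), so a group of one heavy atom on this ring does not by itself return the series to the level of compound 1. The upper end of the read-out now holds most of the compounds shown: the limit of > 100000 nM in this assay, at which 2 of the 3 values shown sit.

Going by these compounds alone, whether the change from compound 1 follows the group or its place on the ring stays open; no pair here alters one alone. On these data alone, how an amine or a carboxylic acid on this ring would read is also open.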